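The compounds below may be only part of what the source reports. "The series", "measured", "known", "first", "only" and "open" are said of these compounds alone.

Compound 1 `O=S(=O)(NCC1COC1)c1cccc(-c2ccc3nccc(-c4ccncc4)c3n2)c1`: 16000 nM
Compound 2 `O=S(=O)(NCc1ccccc1)c1cccc(Nc2ccc3nccc(-c4ccncc4)c3n2)c1`: > 50000 nM

For the measured compounds named here, in an ADME assay on CHO cells (Cricetulus griseus) for cytotoxicity, read by MTT assay (a higher number here means a weaker inhibitor, a lower number a stronger inhibitor), compound 1 gives 16000 nM, the only outright number among the two values shown. For compound 2 the result is a limit of the assay, > 50000 nM, which is the limit of > 50000 nM in this assay, at which 1 of the 2 values shown sits. Compound 3 `CS(=O)(=O)c1cccc(-c2ccc3nccc(-c4ccncc4)c3n2)c1` is not yet measured; it differs from compound 1 by methyl in place of ((oxetan-3-yl)methyl)amino on a sulfonyl sulfur, a change on a sulfonyl sulfur whose other neighbour is aromatic carbon. Going by the values given here, with no measured step to lean on, the expected step of a 1.3-fold higher number from compound 1 to compound 3 (0.10 log units; within the scatter) is none beyond the usual scatter, if anything toward a weaker inhibitor. Compound 3 is therefore estimated at 20000 nM, within 8000 nM to 50000 nM.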

Compound 3, half-maximal inhibitory concentration: 13000 nM
Compound 3: the middle estimate sits 1.5-fold (0.19 log units) above what was measured, and the stated range covers the measured number.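

In this assay, for the compounds shown here, the change on the sulfonyl sulfur is the first step that can be read: a 1.2-fold lower number from compound 1 to compound 3 (0.09 log units; within the scatter). Losing the ((oxetan-3-yl)methyl)amino group, with its four-membered ring and its hydrogen-bond donor, thus leaves the number within the scatter, so at this place methyl and that larger group read alike. Nothing shown here gives a reason for this.

Still open, on these data alone, is whether a carboxylic acid, a basic amine or a longer chain on the same sulfonyl sulfur would also leave the number within the scatter.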